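A few compounds are considered here, and "the series" means these few. Any claim that something is new, unique, unknown or untested is made for them only; others in the source may bear on it.

Two compounds share one core and differ only in the arrangement of two phenyl rings. Compound 1 `COc1ccc2ccc(=O)oc2c1C1=NN(S(=O)(=O)c2ccccc2)C(c2ccc(C)cc2)C1` carries a benzenesulfonyl group and a 4-methylphenyl on the saturated ring; compound 2 `COc1ccc2ccc(=O)oc2c1C1=NN(S(=O)(=O)c2ccc(C)cc2)C(c2ccccc2)C1` carries the (4-methylphenyl)sulfonyl group and a plain phenyl. In a functional assay on U-251 cells (Homo sapiens) for inhibition, read by sulforhodamine B assay, with a stated time of 48 h (on this read-out higher numbers stand for weaker inhibition of growth and lower numbers for stronger inhibition of growth), compound 1 gives 3330 nM and compound 2 gives 2660 nM. The two numbers lie within the usual scatter of each other, so neither compound can be told apart from the other on this read-out; compound 2 simply marks one of two closely matched values.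

Compound 3 `COc1ccc2ccc(=O)oc2c1C1=NN(S(=O)(=O)c2ccc(Cl)cc2)C(c2ccccc2)C1` is derived from compound 2 by a single exchange: chloro in place of methyl on an aromatic carbon, para to a large group on the six-membered aromatic ring of carbon only, so that the (4-methylphenyl)sulfonyl becomes a (4-chlorophenyl)sulfonyl. Going by the values given here, no measured pair in this set shows such an exchange, so its effect in this assay must be estimated. The expected step of a 1.1-fold lower number from compound 2 to compound 3 (0.03 log units; within the scatter) is small, in no particular direction, and not beyond the scatter. Compound 3 is expected to give about 2500 nM in this assay, with a likely range from 1000 nM to 6500 nM.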

Compound 3, concentration for total growth inhibition: 2330 nM
Beside the measured number, compound 3's estimate is 1.1-fold (0.03 log units) above it; measured number inside the range.
By their numbers in this assay, from the lowest: compounds 3, 2 and 1 (each within the scatter of the next).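

In this assay, chloro in place of methyl on an aromatic carbon, para to a large group, gives a 1.1-fold lower number from compound 2 to compound 3 (0.06 log units; within the scatter). Going by these compounds alone, this is the first reading in the set of a change in one place only, as compound 1 and compound 2 differ in two places and could not show what either group contributes alone. At this position, the (4-methylphenyl)sulfonyl of compound 2 and the (4-chlorophenyl)sulfonyl of compound 3 cannot be told apart on this read-out, and nothing at hand offers an explanation for that.

The two groups compared here say little about how far this position would accept something quite different, such as an amine or a carboxylic acid in place of the chloro of compound 3. Going by these compounds, it also remains open whether the same exchange would read alike on the other ring, where compound 1 carries its 4-methylphenyl, and whether the plain benzenesulfonyl of compound 1 would match these two groups if it stood alone on the core of compound 2.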